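Hydroxy in place of hydrogen on compound 1

The compounds below may be only part of what the source reports. "The series", "measured", "known", "first", "only" and "open" are said of these compounds alone.

Compound 1 `COc1ccc(/C=C/C(=O)c2cccc(-c3cccc(F)c3)c2)cc1` holds the lowest number of the three measured in a functional assay on A549 cells (Homo sapiens) for cytotoxicity, read by sulforhodamine B assay, with a stated time of 48 h (on this read-out lower numbers stand for stronger inhibition and higher numbers for weaker inhibition), giving 2440 nM. In this assay compound 3 `COc1ccc(/C=C/C(=O)c2ccc(N)c(-c3ccc(F)cc3)c2)cc1OC` gives 8630 nM, and compound 2 `Nc1ccc(C(=O)/C=C/c2ccc(O)c(F)c2)cc1-c1ccc(F)cc1` gives 24500 nM; both of these gaps to compound 1 lie beyond the scatter. Compound 4 `COc1ccc(/C=C/C(=O)c2cccc(-c3cccc(F)c3)c2)cc1O` differs from compound 1 in one place: hydroxy in place of hydrogen on an aromatic carbon. Among the measured compounds shown here, no pair of measured compounds shows this change, so the size of its effect in this assay is unknown; the expectation is a step of no more than the scatter, with no firm direction. Compound 4 is therefore expected to give about 3000 nM, ranging from 1200 nM to 8000 nM. The expected step of a 1.2-fold higher number from compound 1 to compound 4 (0.09 log units; within the scatter) would stay within the usual scatter.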

Compound 4, half-maximal inhibitory concentration: 500 nM
Compound 4: the middle estimate sits 6.0-fold (0.78 log units) above what was measured; measured number outside the range, below it.
By their numbers in this assay, from the lowest: compound 4; then compound 1; then compound 3; then compound 2.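

In this assay, among the compounds shown here, the change gives a 4.9-fold lower number from compound 1 to compound 4 (0.69 log units; beyond the scatter) and is the first single-place step readable. It shows that this aromatic carbon, ortho to a methoxy group and meta to a large group, responds to hydroxy in place of hydrogen, and that the number moves down rather than up. No measurement at hand explains this step.

Open, from the compounds shown here alone, is whether a carboxylic acid or an acetamide on this carbon would move the number as far. Also open, going by these compounds, is whether the same step would appear on the core of compound 2 or compound 3.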